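Moving a fluorine on the sulfonyl aryl group

The compounds below may be only part of what the source reports. "The series", "measured", "known", "first", "only" and "open" are said of these compounds alone.

Three compounds share one core and differ only in the aryl group on the sulfonyl sulfur. In an assay on isolated protein for displacement of a labelled ligand from metabotropic glutamate receptor 5 (Homo sapiens), with a stated time of 60 min, tested at 1 uM (a higher number here means more inhibition at the concentration tested (going by the name of the read-out), a lower number less inhibition), compound 1 `CC1CCN(c2c(S(=O)(=O)c3cccc(Cl)c3)cnc3ccc(Cl)cc23)CC1` gives 92%. Compound 2 `COc1ccc(S(=O)(=O)c2cnc3ccc(Cl)cc3c2N2CCC(C)CC2)cc1Cl` gives 46% in this assay, and compound 3 `CC1CCN(c2c(S(=O)(=O)c3ccc(F)c(F)c3)cnc3ccc(Cl)cc23)CC1` gives 72%. On these numbers compound 3 stands second highest of three: the step of a number 20 percentage points lower from compound 1 to compound 3 (beyond the scatter) separates it from compound 1, and the step of a number 26 percentage points higher from compound 2 to compound 3 (beyond the scatter) separates it from compound 2.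

Compound 4 `CC1CCN(c2c(S(=O)(=O)c3cc(F)cc(F)c3)cnc3ccc(Cl)cc23)CC1` is not yet measured. It differs from compound 3 by 3,5-difluorophenyl in place of 3,4-difluorophenyl on a sulfonyl sulfur.

For the measured compounds named here, no measured step moves one fluorine around an otherwise unchanged ring. Going by the values given here, the steps that bear on it are those that alter the sulfonyl aryl group: a number 46 percentage points lower from compound 1 to compound 2 (beyond the scatter), which added a methoxy group; a number 20 percentage points lower from compound 1 to compound 3 (beyond the scatter); and a number 26 percentage points higher from compound 2 to compound 3 (beyond the scatter). Each of these steps changed the inhibition beyond the scatter, so a change of this kind is clearly felt in this assay, yet none of them points in a fixed direction for compound 4. He therefore expects a step of a number 3 percentage points higher from compound 3 to compound 4 (within the scatter) that stays within or near the scatter. His estimate for compound 4 in this assay is 75%, with a range from 55% to 90%.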

Compound 4, a percentage reported as inhibition, at one concentration (the size of the read-out at that concentration, not a potency): 93%
Compound 4: middle estimate off by 18 percentage points, on the low side, and the stated range ends below it.
By their numbers in this assay, from the lowest: compound 2; then compound 3; then compounds 1 and 4 (each within the scatter of the next).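

For the compounds shown here, compounds 3 and 4 have the same atoms and differ only in where one fluorine sits on the sulfonyl aryl group, and in this assay a number 21 percentage points higher from compound 3 to compound 4 (beyond the scatter) shows that this placement alone is enough to change the inhibition, something the earlier steps could not isolate because each also changed the substituents themselves. Going by these compounds alone, with a number 1 percentage points higher from compound 1 to compound 4 (within the scatter), 3,5-difluorophenyl is level with 3-chlorophenyl, while a number 47 percentage points higher from compound 2 to compound 4 (beyond the scatter) is the largest gain among the new steps, so across these four compounds the two aryl groups with a substituent numbered 4 in their names, 3,4-difluorophenyl and 3-chloro-4-methoxyphenyl, give the lower numbers, and no compound here goes against that. Nothing shown accounts for the difference between the two difluorophenyl groups.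

The compounds shown leave open whether that pattern holds for other groups, such as 4-fluorophenyl, 3,5-dichlorophenyl or 3,5-dimethylphenyl, or for a plain phenyl ring on the sulfonyl sulfur. Going by these compounds, since compounds 1 and 4 are compared at a single concentration, how they stand in potency also remains open.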